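Methoxy for methylsulfonyl on a sulfonate ester series

This account rests on a few compounds, and the source may have more. Where it says the series, first, only, none or still open, it means among the compounds named here.

Two sulfonate esters sharing one core have been measured in an assay (strain Sprague-Dawley) for inhibition of Amine oxidase [flavin-containing] B (Rattus norvegicus), read by spectrophotometry, with a stated time of 5 min, tested at 10 uM; on this read-out lower numbers stand for less inhibition and higher numbers for more inhibition at the one concentration tested (going by the name of the read-out). Compound 1 `CNC(=O)/C=C1/COc2cc(OS(=O)(=O)c3ccc(C(C)=O)cc3)ccc21` carries an acetyl on the outer aromatic ring, and in this assay compound 1 gives 0%. Compound 2 `CNC(=O)/C=C1/COc2cc(OS(=O)(=O)c3ccc(S(C)(=O)=O)cc3)ccc21` carries a methylsulfonyl in the same place, and in this assay compound 2 gives 0%. The single step between them, no change at the digits printed from compound 1 to compound 2 (within the scatter), thus stands within the scatter, and compound 2 is level with compound 1 on the numbers shown.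

Compound 3 `CNC(=O)/C=C1/COc2cc(OS(=O)(=O)c3ccc(OC)cc3)ccc21` is the next member, not yet measured. Its difference from compound 2 is methoxy in place of methylsulfonyl on an aromatic carbon. For the measured compounds named here, the only measured step that bears on it is the exchange of one group for another at this same aromatic carbon, no change at the digits printed from compound 1 to compound 2 (within the scatter), which was flat. With both measured compounds showing no inhibition at the single concentration tested, there is no basis for expecting a shift in either direction, and the step from compound 2 to compound 3 is expected to be no change at the digits printed from compound 2 to compound 3 (within the scatter), within the scatter. Compound 3 is therefore estimated at 0%, in the range -8% to 12%.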

Compound 3, a percentage reported as inhibition, at one concentration (the size of the read-out at that concentration, not a potency): 0%
The estimate for compound 3 equals the measured number at the digits printed, and the stated range covers the measured number.
By their numbers in this assay, from the lowest: compounds 1, 2 and 3 (each within the scatter of the next).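

In this assay, methoxy in place of methylsulfonyl gives no change at the digits printed from compound 2 to compound 3 (within the scatter) and methoxy in place of acetyl gives no change at the digits printed from compound 1 to compound 3 (within the scatter). The flat reading at this aromatic carbon, para to a large group, therefore no longer rests on a single exchange: it now holds across three groups, and methoxy brings fewer heavy atoms and fewer hydrogen-bond acceptors than methylsulfonyl and no double bond outside the aromatic rings. No further measurement accounts for why the three compounds read alike.

With all three compounds level, the series gives no order among these groups and does not show whether any group at this carbon can raise the inhibition at the one concentration tested. From the compounds shown here alone, it remains open whether an amine or a carboxylic acid at this carbon, or a longer chain on the amide nitrogen of the shared core, would give a reading that stands clear of the scatter.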